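Compound 4 reshapes the group on the carbonyl carbon

A few compounds are considered here, and "the series" means these few. Any claim that something is new, unique, unknown or untested is made for them only; others in the source may bear on it.

Three measured compounds share one core and differ only in the group on a carbonyl carbon. Compound 1 `O=C(NC1CCN(Cc2ccn(-c3ccc(C(F)(F)F)cc3)c2)CC1)N1CCCC1Cc1cccnc1` gives 26 nM in an assay on HEK293 cells for displacement of a labelled ligand from melanin-concentrating hormone receptor 1 (Homo sapiens); on this read-out higher numbers stand for weaker inhibition and lower numbers for stronger inhibition. Compound 2 `O=C(NC1CCN(Cc2ccn(-c3ccc(C(F)(F)F)cc3)c2)CC1)N1CC[C@@H](O)C1` gives 138 nM in this assay, a change of a 5.3-fold higher number from compound 1 to compound 2 (0.72 log units; beyond the scatter). Compound 3 `O=C(NC1CCN(Cc2ccn(-c3ccc(C(F)(F)F)cc3)c2)CC1)N1CCCCC1CCO` gives 39 nM in this assay; it stands second highest of the three numbers, with a 1.5-fold higher number from compound 1 to compound 3 (0.18 log units; within the scatter) and a 3.5-fold lower number from compound 2 to compound 3 (0.55 log units; beyond the scatter).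

Compound 4 `O=C(NCC1(O)CCCCC1)NC1CCN(Cc2ccn(-c3ccc(C(F)(F)F)cc3)c2)CC1` is not yet measured. It differs from compound 3 by ((1-hydroxycyclohexyl)methyl)amino in place of 2-(2-hydroxyethyl)piperidin-1-yl on a carbonyl carbon. The three measured steps each exchanged one ring-bound group for another at the same carbonyl carbon, and the largest of them, a 5.3-fold higher number from compound 1 to compound 2 (0.72 log units; beyond the scatter), was modest. None of them exchanged a ring-bound group for an amino group as here, so they bear on this step only loosely. A modest step is therefore expected, in the direction of a higher number, a 2.1-fold higher number from compound 3 to compound 4 (0.31 log units; beyond the scatter). Compound 4 is expected to give 80 nM in this assay, within a range from 25 nM to 250 nM.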

Compound 4, half-maximal inhibitory concentration: 44 nM
Beside the measured number, compound 4's estimate is 1.8-fold (0.26 log units) above it; low and high end bracket the measured number.
By their numbers in this assay, from the lowest: compounds 1, 3 and 4 (each within the scatter of the next); then compound 2.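

Moving the nitrogen out of the ring changes little at this carbonyl carbon: ((1-hydroxycyclohexyl)methyl)amino in place of 2-(2-hydroxyethyl)piperidin-1-yl, the same atoms joined differently with one more hydrogen-bond donor, gives a 1.1-fold higher number from compound 3 to compound 4 (0.05 log units; within the scatter) in this assay. The group with its nitrogen outside the ring also stays level with the 2-((pyridin-3-yl)methyl)pyrrolidin-1-yl group, at a 1.7-fold higher number from compound 1 to compound 4 (0.23 log units; within the scatter), while it clearly improves on 3-hydroxypyrrolidin-1-yl, at a 3.1-fold lower number from compound 2 to compound 4 (0.50 log units; beyond the scatter). No measurement shown accounts for these results.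

Going by these compounds, it remains open whether the hydroxyl of the new group counts for anything, as a plain cyclohexylmethylamino group or a methoxy in its place would show. Also open, on these data alone, is how an open-chain amine such as 2-hydroxyethylamino would compare at this carbonyl carbon.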